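The source may report more compounds than this note shows. Statements on the series, on what has been measured and on what is new or still open speak of the compounds shown alone.

Working notes. The core shared by the series is that of compound 1 `CCN(CC)CCCNC(=O)c1ccc(C(CC)(CC)c2ccc(OCC(O)C(C)(C)C)c(C)c2)n1CC`, which in an assay on HL-60 cells for agonist activity at vitamin D3 receptor (Homo sapiens), read by microscopy, with a stated time of 96 h (on this read-out lower numbers stand for an effect already at smaller amounts and higher numbers for an effect only at larger amounts of compound), gives 66 nM. For the measured compounds named here, compound 2 `CCn1c(C(=O)N(C)CC(=O)O)ccc1C(CC)(CC)c1ccc(OCC(O)C(C)(C)C)c(C)c1` gives 740 nM in this assay, the highest of the two numbers measured so far; its nearest neighbour is compound 1, reached by the single measured step of an 11-fold higher number from compound 1 to compound 2 (1.05 log units; beyond the scatter). Compound 3 `CCOc1ccc(NC(=O)c2ccc(C(CC)(CC)c3ccc(OCC(O)C(C)(C)C)c(C)c3)n2CC)cc1` has not yet been measured. Its change from compound 2 is (4-ethoxyphenyl)amino in place of (carboxymethyl)(methyl)amino on a carbonyl carbon. Going by the values given here, the only step bearing on this position is the one on the same carbonyl carbon, which was large. No (4-ethoxyphenyl)amino analogue has been measured, so the direction rests on one step alone. Because an 11-fold higher number from compound 1 to compound 2 (1.05 log units; beyond the scatter) rose sharply when (3-(diethylamino)propyl)amino gave way to (carboxymethyl)(methyl)amino, the reverse move away from (carboxymethyl)(methyl)amino is expected to lower the number again, and the step of an 8.2-fold lower number from compound 2 to compound 3 (0.91 log units; beyond the scatter) is expected to be a decrease beyond the scatter. Compound 3 is estimated at 90 nM, with a range from 20 nM to 450 nM.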

Compound 3, half-maximal effective concentration: 630 nM
Estimate against measurement, compound 3: 7.0-fold (0.85 log units) below; the whole stated range lies below it.
By their numbers in this assay, from the lowest: compound 1; then compounds 3 and 2 (each within the scatter of the next).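

In this assay, (4-ethoxyphenyl)amino in place of (carboxymethyl)(methyl)amino on the carbonyl carbon gives a 1.2-fold lower number from compound 2 to compound 3 (0.07 log units; within the scatter) and so leaving the carboxymethyl-bearing group does not by itself restore a low number. On the amide-type nitrogen, 4-ethoxyphenyl in place of 3-(diethylamino)propyl gives a 9.5-fold higher number from compound 1 to compound 3 (0.98 log units; beyond the scatter) and so, among these three compounds, the low number stays with the 3-(diethylamino)propyl group alone, while two groups that share neither a ring count nor a heavy-atom count read alike. Nothing available explains this likeness.

Open, on these data alone, is whether the diethylamino end or the propyl chain matters more. A 3-hydroxypropyl group, a shorter chain ending in a diethylamino group, or a 4-(diethylamino)phenyl group on the same nitrogen would separate these.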